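A few compounds are considered here, and "the series" means these few. Any claim that something is new, unique, unknown or untested is made for them only; others in the source may bear on it.

The measured compounds in this series are:

compound 1 `Nc1sc(-c2ccc(Cl)cc2)c(-c2ccc(Cl)cc2)c1C(=O)N1CCCC1`, 6220 nM
compound 2 `Nc1sc(-c2ccc(F)cc2)c(-c2ccc(Cl)cc2)c1C(=O)N1CCCC1`, 20400 nM
compound 3 `Nc1sc(-c2ccc(Br)cc2)c(-c2ccc(Cl)cc2)c1C(=O)N1CCCC1`, 37500 nM

In a functional assay on PC-3 cells (Homo sapiens) for cytotoxicity, read by sulforhodamine B assay, with a stated time of 72 h (a higher number here means a weaker inhibitor, a lower number a stronger inhibitor), compound 1 gives 6220 nM, the lowest of the three numbers. The nearest is compound 2, and the step is a 3.3-fold higher number from compound 1 to compound 2 (0.52 log units; beyond the scatter); the furthest is compound 3, with a 6.0-fold higher number from compound 1 to compound 3 (0.78 log units; beyond the scatter). Between compound 2 and compound 3 the step is a 1.8-fold higher number from compound 2 to compound 3 (0.26 log units; within the scatter). All three of these steps concern a halogen on a phenyl group and leave the rest of the shared core untouched.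

Compound 4 `CC(C)(C)NC(=S)c1c(N)sc(-c2ccc(Cl)cc2)c1-c1ccc(Cl)cc1` is a different matter. Compared with compound 1 it carries a group of 7 heavy atoms (5 carbon, 1 nitrogen, 1 sulfur; no ring) in place of a group of 7 heavy atoms (5 carbon, 1 nitrogen, 1 oxygen; one five-membered non-aromatic ring with 1 hetero atom), on an aromatic carbon. For the measured compounds named here, no measured step touches this part of the shared core, so none of the three steps bears on the change from compound 1 to compound 4; the only guidance is that the halogen swaps each moved the number by a modest amount. Going by the values given here, with no comparable step in hand, compound 4 is expected to land near compound 1, as a step of a 1.2-fold lower number from compound 1 to compound 4 (0.09 log units; within the scatter), but with wide uncertainty. The estimate for compound 4 in this assay is 5000 nM, within a range from 800 nM to 30000 nM.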

Compound 4, half-maximal inhibitory concentration: 34000 nM
Compound 4: the middle estimate sits 6.8-fold (0.83 log units) below what was measured, outside the stated range (above it).
By their numbers in this assay, from the lowest: compound 1; then compounds 2, 4 and 3 (each within the scatter of the next).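

In this assay, the swap on this aromatic carbon of the five-membered aromatic ring with 1 sulfur gives a clear change (a 5.5-fold higher number from compound 1 to compound 4 (0.74 log units; beyond the scatter)), which shows that the number responds to this position as well as to the halogen on the phenyl group. The entering group differs from (pyrrolidin-1-yl)carbonyl in several ways at once: it has no ring, it carries sulfur where the group that leaves carries oxygen, and it adds a hydrogen-bond donor, so this single step cannot assign the shift to any one of these differences. Nothing measured on these compounds accounts for the shift.

The compounds shown leave open whether a thiocarbonyl that keeps the pyrrolidine ring, or a carbonyl that bears a tert-butylamino group, would account for the shift on its own, and so which part of the exchange matters. They also leave open how a piperidine amide, a morpholine amide or a free carboxylic acid at this position would read, and whether the halogen steps seen with the pyrrolidine group would hold with a different group here.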